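Moving two chlorines on the outer ring of compound 3

The compounds below may be only part of what the source reports. "The series", "measured", "known", "first", "only" and "open" are said of these compounds alone.

Compound 1 `O=C(/C=C/c1ccc(Oc2ncnc3ccc(Cl)cc23)cc1)/C=C/c1cc([N+](=O)[O-])ccc1Cl`: 76.8%
Compound 2 `O=C(/C=C/c1ccc(Oc2ncnc3ccc(Cl)cc23)cc1)/C=C/c1ccc(Cl)c([N+](=O)[O-])c1`: 56.3%
Compound 3 `O=C(/C=C/c1ccc(Oc2ncnc3ccc(Cl)cc23)cc1)/C=C/c1ccc(Cl)c(Cl)c1`: 33.5%

In a functional assay on PC-3 cells (Homo sapiens) for inhibition, read by MTT assay, with a stated time of 72 h, tested at 10 uM (a lower number here means less inhibition of growth, a higher number more inhibition of growth at the concentration tested), compound 3 stands lowest of the three measured compounds: the step of a number 43.3 percentage points lower from compound 1 to compound 3 (beyond the scatter) is large, and the step of a number 22.8 percentage points lower from compound 2 to compound 3 (beyond the scatter) is modest, both beyond the scatter. Compound 4 `O=C(/C=C/c1ccc(Oc2ncnc3ccc(Cl)cc23)cc1)/C=C/c1cccc(Cl)c1Cl` keeps the shared core and differs from compound 3 only in the outer ring: 2,3-dichlorophenyl in place of 3,4-dichlorophenyl on a double-bonded chain carbon bound to a double-bonded chain carbon. Among the measured compounds shown here, no measured step swaps chlorines between positions on an otherwise unchanged ring. The step of a number 20.5 percentage points lower from compound 1 to compound 2 (beyond the scatter) rearranged a chloro and a nitro group, and the steps from compound 1 and compound 2 to compound 3 exchanged a nitro for a chloro; none of these tells how two chlorines alone respond to a change of position. The expected step of a number 1.5 percentage points higher from compound 3 to compound 4 (within the scatter) is therefore small, possibly within the scatter, with a wide range of uncertainty. Compound 4 is estimated at 35%, between 15% and 55%.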

Compound 4, percent growth inhibition at one concentration: 67.4%
Estimate against measurement, compound 4: 32.4 percentage points below; measured number outside the range, above it.
By their numbers in this assay, from the lowest: compound 3; then compound 2; then compounds 4 and 1 (each within the scatter of the next).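

Rearrangement alone moves the number: in this assay the step is a number 33.9 percentage points higher from compound 3 to compound 4 (beyond the scatter), with 2,3-dichlorophenyl replacing 3,4-dichlorophenyl and the atoms of the ring unchanged. A nitro group is also not required for this level of growth inhibition, since the dichlorinated ring gives a number 11.1 percentage points higher from compound 2 to compound 4 (beyond the scatter) and a number 9.4 percentage points lower from compound 1 to compound 4 (within the scatter). Among these four compounds, the 2,3-dichlorophenyl of compound 4 and the 2-chloro-5-nitrophenyl of compound 1 both carry a chlorine at the 2 position and give the two higher numbers, and neither of the other two compounds goes against this.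

Nothing shown here explains why the arrangement matters. From the compounds shown here alone, whether a methoxy group or an amine could take the place of either chlorine on the 2,3-dichlorophenyl ring and keep this level of inhibition remains open.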